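Amine substituents on a shared core: expecting compound 3

A few compounds are considered here, and "the series" means these few. Any claim that something is new, unique, unknown or untested is made for them only; others in the source may bear on it.

- compound 1 `COc1cc(C)cc2c1C(=O)C=C(c1c(C)cc3c(c1OC)C(=O)C(Nc1ccc4ccccc4c1)=CC3=O)C2=O`: 73800 nM
- compound 2 `CCOC(=O)CNC1=CC(=O)c2cc(C)c(C3=CC(=O)c4c(OC)cc(C)cc4C3=O)c(OC)c2C1=O`: 96200 nM

In an ADME assay on PBMC cells (Homo sapiens) for cytotoxicity, read by MTT assay, with a stated time of 24 h (a lower number here means a stronger inhibitor, a higher number a weaker inhibitor), compound 2 gives 96200 nM and cannot be told apart from compound 1 on these numbers. Among the compounds with values here, the one measured step, a 1.3-fold higher number from compound 1 to compound 2 (0.12 log units; within the scatter), places (ethoxycarbonyl)methyl in place of naphthalen-2-yl on an amine nitrogen and stays within the scatter.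

Compound 3 `COc1cc(C)cc2c1C(=O)C=C(c1c(C)cc3c(c1OC)C(=O)C(NC(C)=O)=CC3=O)C2=O` awaits measurement. Its difference from compound 2 is acetyl in place of (ethoxycarbonyl)methyl on an amine nitrogen, which also reads ((ethoxycarbonyl)methyl)amino to acetamido. Within the data shown here, only the step from compound 1 bears on this nitrogen. Among the measured compounds shown here, it is a single step, and no measured compound carries acetyl, so the support is thin.

Even so, the exchange of two quite different groups in a 1.3-fold higher number from compound 1 to compound 2 (0.12 log units; within the scatter) left the number within the scatter, and the same is expected here. In this assay the expected change is a 1.1-fold lower number from compound 2 to compound 3 (0.05 log units; within the scatter), with no step beyond the scatter expected. For compound 3 the estimated value is 85000 nM, with an expected range from 45000 nM to 150000 nM.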

Compound 3, half-maximal inhibitory concentration: 86500 nM
The estimate for compound 3 lay 1.0-fold (0.01 log units) below the measured number, within the range that was stated.
By their numbers in this assay, from the lowest: compounds 1, 3 and 2 (each within the scatter of the next).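

In this assay the amine nitrogen on the shared core now has a third substituent: acetyl in place of (ethoxycarbonyl)methyl gives a 1.1-fold lower number from compound 2 to compound 3 (0.05 log units; within the scatter) and acetyl in place of naphthalen-2-yl gives a 1.2-fold higher number from compound 1 to compound 3 (0.07 log units; within the scatter) as a second reading of the same exchange. The earlier pair showed only that an ester-bearing chain and a naphthalen-2-yl group could not be told apart; the acetamido form, with its carbonyl carried directly on the nitrogen, also falls within the scatter of both, so all three compounds read alike and no substituent at this nitrogen can be ranked over another. The observation is limited to these three compounds, and no supporting measurement accounts for the absence of a readable step at this nitrogen.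

On these data alone, whether an unsubstituted amino group, a carboxylic acid in place of the ethyl ester, or a longer chain on this nitrogen would move the number beyond the scatter remains open. These compounds also leave open whether changes elsewhere on the shared core would give a readable step in this cytotoxicity read-out.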